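This account rests on a few compounds, and the source may have more. Where it says the series, first, only, none or still open, it means among the compounds named here.

Notes on the series. Compound 1 `CCC1C(=O)N(C)c2cnc(-n3ccc4cc(C(N)=O)ccc43)nc2N1c1ccn(C)n1` is recorded in a functional assay on MCF7 cells (Homo sapiens) for antiproliferative activity, read by CCK-8 assay, with a stated time of 72 h (on this read-out lower numbers stand for stronger inhibition of growth and higher numbers for weaker inhibition of growth), only as "not active" (no number reported), with no numerical value behind it, so its standing among the numbered compounds cannot be fixed. For comparison, compound 2 `CC[C@@H]1C(=O)N(C)c2cnc(Nc3ccc(S(N)(=O)=O)cc3)nc2N1C1CCCC1` gives 394 nM in this assay, while compound 3 `CCC1C(=O)N(C)c2cnc(Nc3ccc(S(=O)(=O)NCC(C)C)cc3)nc2N1c1ccn(C)n1` gives 8350 nM. Compound 4 `CCC1C(=O)N(C)c2cnc(-n3ccc4cc(C(=O)NCC(C)C)ccc43)nc2N1c1ccn(C)n1` carries the change (isobutyl in place of hydrogen on an amide-type nitrogen). Among the measured compounds shown here, no measured step between related compounds describes this change, and the starting point has no number, so the direction cannot be read from a step; the other member carrying an isobutyl group, compound 3, sits at 8350 nM. Compound 4 is therefore expected to remain weak, with an estimated value of 12000 nM and a range from 2500 nM to 60000 nM.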

Compound 4, concentration for 50% growth inhibition: 4810 nM
Estimate against measurement, compound 4: 2.5-fold (0.40 log units) above, within the range that was stated.
By their numbers in this assay, from the lowest: compound 2; then compounds 4 and 3 (each within the scatter of the next).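

Among the compounds shown here, compound 1 carries no number in this assay, and no step to compound 4 can be read from it. The compounds shown leave open what isobutyl in place of hydrogen on the amide-type nitrogen changes in this assay. No evidence bears on this result.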